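The source may hold more compounds than are shown below. What is called first, only, known or untested is meant among the compounds shown, and "the series" means these compounds.

Working notes on the series in a functional assay on MCF7 cells (Homo sapiens) for antiproliferative activity, read by sulforhodamine B assay, with a stated time of 3 days; a lower number here means a stronger inhibitor, a higher number a weaker inhibitor. Compound 1 (`c1ccc(Oc2ncnc3c2ncn3C2COc3ccccc3CO2)cc1`) gives 24700 nM, compound 2 (`C=CCOc1ncnc2c1ncn2C1COc2ccccc2CO1`) gives 5040 nM and compound 3 (`Fc1ccc(Sc2ncnc3c2ncn3C2COc3ccccc3CO2)cc1`) gives 11200 nM. Compound 3 therefore holds the second highest of the three numbers, and it is separated from both others by gaps beyond the scatter: a 2.2-fold lower number from compound 1 to compound 3 (0.34 log units; beyond the scatter) and a 2.2-fold higher number from compound 2 to compound 3 (0.35 log units; beyond the scatter).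

The next compound is compound 4 (`CSc1ncnc2c1ncn2C1COc2ccccc2CO1`), and the change is methyl in place of 4-fluorophenyl on a sulfur. In words, this is methyl in place of 4-fluorophenyl on a sulfur.

Going by the values given here, no measured step makes this change on a sulfur. Among the compounds with values here, the nearest precedent is a 4.9-fold lower number from compound 1 to compound 2 (0.69 log units; beyond the scatter), with allyl in place of phenyl on an oxygen, which also replaces an aromatic ring with a group that has none. The step of a 2.2-fold higher number from compound 2 to compound 3 (0.35 log units; beyond the scatter) read in reverse points the same way, but it changes the linking atom as well. Both steps are modest, and the evidence rests on these three compounds alone.

A modest move towards a lower number is therefore expected, smaller than the precedent on oxygen. The expected step is a 2.0-fold lower number from compound 3 to compound 4 (0.31 log units; beyond the scatter). For compound 4 the estimated value is 5500 nM, with an expected range of 2300 nM to 13000 nM.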

Compound 4, half-maximal inhibitory concentration: 24000 nM
For compound 4 the middle estimate is 4.4-fold (0.64 log units) below the measured one; the whole stated range lies below it.
By their numbers in this assay, from the lowest: compound 2; then compound 3; then compounds 4 and 1 (each within the scatter of the next).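

On the sulfur, methyl in place of 4-fluorophenyl gives a 2.1-fold higher number from compound 3 to compound 4 (0.33 log units; beyond the scatter), the opposite direction to the allyl-for-phenyl change on oxygen, a 4.9-fold lower number from compound 1 to compound 2 (0.69 log units; beyond the scatter), so in this assay replacing an aromatic ring with a group that has none has no single direction across these compounds. The methylsulfanyl and phenoxy compounds stand level (a 1.0-fold lower number from compound 1 to compound 4 (0.01 log units; within the scatter)), while allyloxy keeps the lowest number in the set (a 4.8-fold higher number from compound 2 to compound 4 (0.68 log units; beyond the scatter)), so the series does not simply reward losing the aromatic ring, and the small methyl on sulfur gains nothing over phenyl on oxygen. No measurement here accounts for the reversal between the sulfur and oxygen changes.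

The compounds shown leave open how much of the difference belongs to the linking atom and how much to the group it carries, a question that methoxy, allylsulfanyl or an unsubstituted phenylsulfanyl group would address directly. They also leave open whether an amine at this aromatic carbon, or a longer chain such as butyl on the sulfur or oxygen, would fall nearer compound 2 or nearer compound 4.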